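This account rests on a few compounds, and the source may have more. Where it says the series, first, only, none or still open, it means among the compounds named here.

Of the compounds shown here, two built on a shared core have so far been measured in a functional assay on DU-145 cells (Homo sapiens) for cytotoxicity, read by MTT assay; on this read-out lower numbers stand for stronger inhibition and higher numbers for weaker inhibition. Compound 1 `COC(C)CO[C@H](CC=C(C)C)C1=CC(=O)c2c(O)ccc(O)c2C1=O` gives 16600 nM. Compound 2 `CCCC(CC(=O)O[C@H](CC=C(C)C)C1=CC(=O)c2c(O)ccc(O)c2C1=O)OC(C)=O` gives 55700 nM, the higher of the two numbers and so the weaker inhibition, and its gap to compound 1 lies beyond the usual scatter of repeated measurements. Compound 3 `CC(C)=CC[C@@H](OC(=O)C1CCOC1)C1=CC(=O)c2c(O)ccc(O)c2C1=O` has not yet been measured.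

Compound 3 differs from compound 2 in a single place: oxolan-3-yl stands in place of 2-acetoxypentyl on a carbonyl carbon (oxolan-3-yl in place of 2-acetoxypentyl on a carbonyl carbon). Among the compounds with values here, no measured pair shows what a change of this kind does, so any forecast rests on very little. Within the data shown here, compound 2 already sits at the top of the small range seen so far, and the only other reference is compound 1 at 16600 nM. A modest move toward lower numbers is therefore expected, near the edge of the scatter, though no change at all would not be surprising. The estimated change is a 2.2-fold lower number from compound 2 to compound 3 (0.35 log units; beyond the scatter). In this assay, the expected value for compound 3 is 25000 nM, with an estimated range from 9000 nM to 60000 nM.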

Compound 3, half-maximal inhibitory concentration: 47500 nM
For compound 3 the middle estimate is 1.9-fold (0.28 log units) below the measured one; the range from low to high includes it.
By their numbers in this assay, from the lowest: compound 1; then compounds 3 and 2 (each within the scatter of the next).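

In this assay the exchange of 2-acetoxypentyl for oxolan-3-yl on a carbonyl carbon gives a 1.2-fold lower number from compound 2 to compound 3 (0.07 log units; within the scatter) and so leaves the number where it was, even though an open chain carrying an acetoxy group gives way to a five-membered non-aromatic ring. Compound 3 also gives the first listed step from compound 1, a 2.9-fold higher number from compound 1 to compound 3 (0.46 log units; beyond the scatter) for (oxolan-3-yl)carbonyl in place of 2-methoxypropyl on an oxygen on a saturated carbon, which puts both compounds with a carbonyl carbon at this place on the weaker side of compound 1 and shows that the gap first seen with compound 2 was not peculiar to its 2-acetoxypentyl group. Nothing beyond these numbers is available to explain either result.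

As far as these compounds go, it remains open whether an amine or a carboxylic acid on the carbonyl carbon, or a longer chain there, would move the number away from the values of compound 2 and compound 3. Also open, from the compounds shown here alone, is whether the gap to compound 1 follows the carbonyl group itself or the groups it carries, a question that a simple acetyl group at this place would begin to address.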